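Swapping Bromo for Methoxy on Compound 1

A few compounds are considered here, and "the series" means these few. Any claim that something is new, unique, unknown or untested is made for them only; others in the source may bear on it.

Within the data shown here, in a functional assay on HCT-116 cells (Homo sapiens) for antiproliferative activity, read by MTT assay, with a stated time of 72 h (on this read-out higher numbers stand for weaker inhibition and lower numbers for stronger inhibition), compound 1 `NC1=NC2(CCSCC2)N(OCCCOc2ccc(Br)cc2)C(N)=N1` gives 20 nM, the lowest of the two numbers measured so far. The other measured molecule, compound 2 `NC1=NC2(CCOCC2)N(OCCCOc2ccc(Cl)cc2Cl)C(N)=N1`, gives 880 nM, and that gap lies well beyond the usual scatter of repeated measurements. Compound 1 therefore marks the stronger end of this small set, though two compounds can show no trend.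

The next molecule, compound 3 `COc1ccc(OCCCON2C(N)=NC(N)=NC23CCSCC3)cc1`, keeps everything in compound 1 except one group: methoxy in place of bromo on an aromatic carbon. In words, methoxy stands in place of bromo on an aromatic carbon, turning 4-bromophenyl into 4-methoxyphenyl.

Compound 1 and compound 2 differ in more than one place, so the data do not show what this swap does on its own. Any forecast is therefore a cautious judgement. Compound 1 already gives 20 nM, so a modest move towards weaker inhibition in this assay seems more likely than a further gain, only slightly beyond the scatter. The expected change is a 3.0-fold higher number from compound 1 to compound 3 (0.48 log units; beyond the scatter). For compound 3, the estimated value is 60 nM, with an expected range from 15 nM to 250 nM.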

Compound 3, half-maximal inhibitory concentration: 70 nM
For compound 3 the middle estimate is 1.2-fold (0.07 log units) below the measured one, and the stated range covers the measured number.
By their numbers in this assay, from the lowest: compound 1; then compound 3; then compound 2.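

Among these compounds, compound 1 and compound 3 form the first pair here that differs in one place only, so the effect of a single change can now be read directly. In this assay, a 3.5-fold higher number from compound 1 to compound 3 (0.54 log units; beyond the scatter) is what methoxy in place of bromo does on this aromatic carbon, para to a large group, which is a modest loss but a real one. Bromo is still not essential for a low number, since compound 3 gives 70 nM in this assay with methoxy at that place, although this single pair cannot show a trend. No measurement given here explains why the number rises with this swap.

Going by these compounds, what a smaller or differently built group would do at this place remains open, for example an amine, a nitrile or a carboxylic acid, and each would need its own comparison with compound 1. On these data alone, it is also open whether the change from 4-bromophenyl to 4-methoxyphenyl would give a step of similar size on the core of compound 2.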